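Moving a Small Alkyl Group Around the Outer Ring

This account rests on a few compounds, and the source may have more. Where it says the series, first, only, none or still open, it means among the compounds named here.

Measured compounds:
compound 1: `COC(=O)C(Cc1cccc(C(=N)N)c1)C(/C=C/c1ccccc1)NC(=O)c1ccc(-c2ccccc2C)cc1`, 3100 nM
compound 2: `COC(=O)C(Cc1cccc(C(=N)N)c1)C(/C=C/c1ccccc1)NC(=O)c1ccc(-c2ccc(C)cc2)cc1`, 2800 nM

Both compounds share one core and differ only in where a methyl group sits on the outer phenyl ring. In an assay on isolated protein (Oryctolagus cuniculus) for inhibition of Trypsin (Homo sapiens) (on this read-out lower numbers stand for stronger inhibition and higher numbers for weaker inhibition), compound 1 gives 3100 nM, and compound 2 gives 2800 nM. For the measured compounds named here, the single measured step, a 1.1-fold lower number from compound 1 to compound 2 (0.04 log units; within the scatter), shows that shifting the methyl from one ring position to another left the read-out essentially unchanged, so compound 2 stands alongside compound 1 rather than apart from it.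

Compound 3 is `CCc1cccc(-c2ccc(C(=O)NC(/C=C/c3ccccc3)C(Cc3cccc(C(=N)N)c3)C(=O)OC)cc2)c1`. Its change from compound 2 is 3-ethylphenyl in place of 4-methylphenyl on an aromatic carbon. Going by the values given here, only the step of a 1.1-fold lower number from compound 1 to compound 2 (0.04 log units; within the scatter) bears on this: it moved a small alkyl group around the same ring and stayed within the scatter. A slightly larger alkyl group at yet another ring position is therefore expected to behave the same way, with an expected step of no change at the digits printed from compound 2 to compound 3 (within the scatter), that is, nothing beyond the scatter. Compound 3 is expected to give about 2800 nM, within a range from 1200 nM to 6500 nM.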

Compound 3, half-maximal inhibitory concentration: 2600 nM
Compound 3: middle estimate off by 1.1-fold (0.03 log units), on the high side; low and high end bracket the measured number.
By their numbers in this assay, from the lowest: compounds 3, 2 and 1 (each within the scatter of the next).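

Replacing the methyl with an ethyl group, and not only moving the methyl, still gives a 1.1-fold lower number from compound 2 to compound 3 (0.03 log units; within the scatter), and the comparison with the 2-methylphenyl ring gives a 1.2-fold lower number from compound 1 to compound 3 (0.08 log units; within the scatter), so neither step stands out from the scatter. The earlier pair covered only a methyl group at two ring positions, whereas the read-out now stays close across three substituted rings and two alkyl groups. Nothing available here explains why these rings read alike.

As far as these compounds go, all three outer rings carry only a small alkyl group, so it remains open whether a group of another kind, such as an amine or a carboxylic acid, would also stay within the scatter. From the compounds shown here alone, it is equally open whether a longer chain, such as butyl, would do so on this ring.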